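Hydrazone Anticancer Series: A Fourth Compound Awaits Its Value

The compounds below may be only part of what the source reports. "The series", "measured", "known", "first", "only" and "open" are said of these compounds alone.

Measured so far:
Compound 1, `CSc1nn(-c2ccccc2)c2ncnc(N/N=C/c3cccc(O)c3)c12`: 10.7 nM
Compound 2, `CSc1nn(-c2ccccc2)c2ncnc(N/N=C/c3ccc(O)cc3)c12`: 10.3 nM
Compound 3, `COc1ccc(-n2nc(SC)c3c(N/N=C/c4cccc(O)c4)ncnc32)cc1`: 9.9 nM

All three compounds share a core carrying a methylthio group and a hydrazone arm that ends in a phenol ring, and all were tested in a functional assay on MCF7 cells (Homo sapiens) for inhibition, read by sulforhodamine B assay, with a stated time of 48 h; a lower number here means a stronger inhibitor, a higher number a weaker inhibitor. Compound 1 gives 10.7 nM in this assay, compound 2 gives 10.3 nM, and compound 3 gives 9.9 nM. The three numbers sit so close together that none can be told apart from the others.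

Two changes have been tried. From compound 1 to compound 2 the phenol is moved: 4-hydroxyphenyl in place of 3-hydroxyphenyl on a carbon with a double bond to nitrogen. The step it made is a 1.0-fold lower number from compound 1 to compound 2 (0.02 log units; within the scatter). From compound 1 to compound 3 the core itself is altered: methoxy in place of hydrogen on an aromatic carbon. That step is a 1.1-fold lower number from compound 1 to compound 3 (0.03 log units; within the scatter).

Compound 4, `COc1ccc(-n2nc(SC)c3c(N/N=C/c4ccc(O)cc4)ncnc32)cc1`, has not yet been measured. It differs from compound 3 by 4-hydroxyphenyl in place of 3-hydroxyphenyl on a carbon with a double bond to nitrogen. This is the same change that turned compound 1 into compound 2, made on the second core, and the place it acts on is described in the same words in both pairs.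

Because the earlier step of a 1.0-fold lower number from compound 1 to compound 2 (0.02 log units; within the scatter) stayed inside the scatter, the expected step on the second core is a 1.0-fold lower number from compound 3 to compound 4 (0.01 log units; within the scatter). Compound 4 is therefore estimated at 9.7 nM in this assay, with a range from 5 nM to 19 nM, resting on compound 3 giving 9.9 nM and on the flatness of the first pair.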

Compound 4, half-maximal inhibitory concentration: 34.4 nM
Beside the measured number, compound 4's estimate is 3.5-fold (0.55 log units) below it, and the stated range ends below it.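

In this assay, the swap of 3-hydroxyphenyl for 4-hydroxyphenyl gives a 3.5-fold higher number from compound 3 to compound 4 (0.54 log units; beyond the scatter), so a change that left no readable mark on the first core does not carry over unchanged to the core with methoxy: the same change on two cores in this assay, a 1.0-fold lower number (0.02 log units; within the scatter) from compound 1 to compound 2 and a 3.5-fold higher number (0.54 log units; beyond the scatter) from compound 3 to compound 4, 3.6-fold (0.56 log units) apart, beyond the scatter of two such steps. The same four compounds can be read the other way round, and the methoxy change, which left no readable mark with 3-hydroxyphenyl, gives a 3.3-fold higher number from compound 2 to compound 4 (0.52 log units; beyond the scatter) with 4-hydroxyphenyl: the same change on two cores in this assay, a 1.1-fold lower number (0.03 log units; within the scatter) from compound 1 to compound 3 and a 3.3-fold higher number (0.52 log units; beyond the scatter) from compound 2 to compound 4, 3.6-fold (0.56 log units) apart, beyond the scatter of two such steps. These two comparisons are one finding seen from two sides: here the two changes do not simply add up, so a flat step on one core was no safe guide to the other, but four compounds cannot show why this happens or how general it is.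

From the compounds shown here alone, all four compounds keep the methylthio group and a hydroxyl on the ring at the end of the hydrazone arm, so it remains open whether an amine or a carboxylic acid in place of that hydroxyl would depend on the core in the same way. Going by these compounds, it is also open whether a longer chain in place of methylthio would change this picture, or whether the gap would appear in other cell lines.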